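Triazole-linked cinnamic acids: a 3-methoxyphenyl analogue

The source may report more compounds than this note shows. Statements on the series, on what has been measured and on what is new or still open speak of the compounds shown alone.

Measured compounds:
- compound 1 `COc1ccc(/C=C\C(=O)O)c(OCc2cn(-c3ccc(NC(C)=O)cc3)nn2)c1CC=C(C)C`: "not determined" (no result reported) in a functional assay on HCT-116 cells (Homo sapiens) for cytotoxicity, read by MTT assay, with a stated time of 24 h; a lower number here means a stronger inhibitor, a higher number a weaker inhibitor
- compound 2 `COc1ccccc1-n1cc(COc2c(/C=C\C(=O)O)ccc(OC)c2CC=C(C)C)nn1`: 32200 nM in this assay
- compound 3 `COc1ccc(/C=C\C(=O)O)c(OCc2cn(-c3ccccc3F)nn2)c1CC=C(C)C`: "not determined" (no result reported) in this assay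

Compound 1 stands without a number of its own in this assay; the only figure in this set comes from compound 2, which gives 32200 nM. Compound 3 likewise has no reported result. Among the compounds with values here, the series therefore offers one weak anchor and no steps between measured compounds.

Compound 4 `COc1cccc(-n2cc(COc3c(/C=C\C(=O)O)ccc(OC)c3CC=C(C)C)nn2)c1` is reached from compound 1 by the change (3-methoxyphenyl in place of 4-acetamidophenyl on an aromatic nitrogen). Within the data shown here, no measured pair isolates this change, so its size and direction cannot be read from the data; the shared core carries the same acid and the same prenyl and methoxy groups in all four compounds. Compound 2 is the closest measured relative of compound 4, and in this assay compound 2 gives 32200 nM. Compound 4 is therefore expected to lie in a similar weak range, with an estimated half-maximal inhibitory concentration in this assay of 30000 nM, with a range from 10000 nM to 90000 nM.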

Compound 4, half-maximal inhibitory concentration: 21600 nM
Estimate against measurement, compound 4: 1.4-fold (0.14 log units) above; the range from low to high includes it.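

Within the data shown here, this is the first step between measured compounds in the set: in this assay, 3-methoxyphenyl in place of 2-methoxyphenyl on an aromatic nitrogen gives a 1.5-fold lower number from compound 2 to compound 4 (0.17 log units; within the scatter). The two methoxyphenyl compounds therefore cannot be told apart here, and compound 4, at 21600 nM, adds a second number to the single one available before. Nothing in the material shown accounts for this result.

Compound 1 and compound 3 have no number of their own, so the change from 4-acetamidophenyl to 3-methoxyphenyl cannot be read as a step. From the compounds shown here alone, whether an amine or a carboxylic acid on this aromatic ring, in place of the methoxy group, would move the value beyond the scatter remains open.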